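Pyrazole ring-nitrogen methylation in the cycloheptyl urea series

This account rests on a few compounds, and the source may have more. Where it says the series, first, only, none or still open, it means among the compounds named here.

Compound 3 `Cc1cc(C)c(NC(=O)N(Cc2cccc(-c3cc[nH]n3)c2)C2CCCCCC2)c(C)c1` gives 65 nM in an assay on microsomes from intestine for inhibition of acyl-CoA:cholesterol acyltransferase (Oryctolagus cuniculus) (on this read-out lower numbers stand for stronger inhibition and higher numbers for weaker inhibition), the highest of the two numbers measured, with compound 2 `Cc1cc(C)c(NC(=O)N(Cc2cccc(-n3cccc3)c2)C2CCCCCC2)c(C)c1` nearest at 20 nM: a 3.3-fold higher number from compound 2 to compound 3 (0.51 log units; beyond the scatter). Compound 1 `Cc1cc(C)c(NC(=O)N(Cc2cccc(-c3nn[nH]n3)c2)C2CCCCCC2)c(C)c1` reaches only a limit of this assay, > 1000 nM, which sits at the limit of > 1000 nM in this assay, at which 1 of the 3 values shown sits. From that limit, an at least 50-fold lower number from compound 1 to compound 2 (1.69 log units; beyond the scatter) and an at least 15-fold lower number from compound 1 to compound 3 (1.18 log units; beyond the scatter).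

Compound 4 `Cc1cc(C)c(NC(=O)N(Cc2cccc(-c3ccn(C)n3)c2)C2CCCCCC2)c(C)c1` differs from compound 3 by methyl in place of hydrogen on an aromatic nitrogen. The measured steps all exchange one five-membered ring for another; none concerns a methyl on a ring nitrogen, so they bear on the step only indirectly. A change of at most modest size in this assay is expected, in no fixed direction. Compound 4 is estimated at 60 nM, within 15 nM to 250 nM. The step of a 1.1-fold lower number from compound 3 to compound 4 (0.03 log units; within the scatter) is expected to stay within the scatter.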

Compound 4, half-maximal inhibitory concentration: 42 nM
Estimate against measurement, compound 4: 1.4-fold (0.15 log units) above; the range from low to high includes it.
By their numbers in this assay, from the lowest: compound 2; then compounds 4 and 3 (each within the scatter of the next). At a limit, above all of these: compound 1.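

Methyl on this ring nitrogen is accepted, with a 1.5-fold lower number from compound 3 to compound 4 (0.19 log units; within the scatter) in this assay and the hydrogen there thus not required for inhibition. The 1-methyl-1H-pyrazol-3-yl group still does not match the 1H-pyrrol-1-yl group, with a 2.1-fold higher number from compound 2 to compound 4 (0.32 log units; beyond the scatter) remaining. The step of an at least 23-fold lower number from compound 1 to compound 4 (1.37 log units; beyond the scatter) starts from a limit of the assay, not a number: the limit of > 1000 nM in this assay, at which 1 of the 4 values shown sits.

Still open, going by these compounds, is whether this nitrogen takes anything larger than methyl, such as ethyl, a longer chain or a chain ending in an amine. Also open, on these data alone, is whether methyl on the 2H-tetrazol-5-yl ring of compound 1 changes its read-out.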